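This account rests on a few compounds, and the source may have more. Where it says the series, first, only, none or still open, it means among the compounds named here.

Compound 1, `O=C(O)c1ccc(Nc2ncnc3sc(Nc4c(Cl)cccc4Cl)nc23)cc1`: in a functional assay on HEK293 cells for antagonist activity at transient receptor potential cation channel subfamily V member 1 (Homo sapiens), read by calcium flux (on this read-out higher numbers stand for weaker inhibition and lower numbers for stronger inhibition), compound 1 gives only a limit, > 5000 nM.
Compound 2, `FC(F)(F)c1ccc(Nc2ncnc3sc(Nc4c(Cl)cccc4Cl)nc23)cc1Cl`: in this assay compound 2 gives 21 nM.
Compound 3, `FC(F)(F)c1ccc(Nc2nc(N3CCNCC3)nc3sc(Nc4c(Cl)cccc4Cl)nc23)cc1`: in this assay compound 3 gives 5000 nM.

Of the two compounds with a number in this assay, compound 3 stands highest; compound 2 sits far lower, a gap well beyond the scatter, while compound 1 shows a limit rather than a number. Compound 4, `CCN(CC)c1nc(Nc2ccc(C(F)(F)F)cc2)c2nc(Nc3c(Cl)cccc3Cl)sc2n1`, has not yet been measured. It differs from compound 3 in one place: diethylamino in place of piperazin-1-yl on an aromatic carbon. Within the data shown here, no step between measured compounds covers a change of this kind, so the expectation rests on the values alone. Compound 2 carries no group at this carbon and gives a much lower number than compound 3; the diethylamino group of compound 4 keeps a substituent there, so compound 4 is expected to land between the two, nearer compound 3, with the step of a 3.3-fold lower number from compound 3 to compound 4 (0.52 log units; beyond the scatter) expected toward stronger inhibition. Compound 4 is estimated at 1500 nM, with a range from 300 nM to 8000 nM.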

Compound 4, half-maximal inhibitory concentration: 48 nM
Estimate against measurement, compound 4: 31-fold (1.49 log units) above; measured number outside the range, below it.
By their numbers in this assay, from the lowest: compound 2; then compound 4; then compound 3.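

In this assay the aromatic carbon between two ring nitrogen atoms turns out to tolerate a substituent with a low number, and exchanging the piperazin-1-yl group for diethylamino gives a 100-fold lower number from compound 3 to compound 4 (2.02 log units; beyond the scatter). The high number of compound 3 therefore goes with the piperazin-1-yl group itself and not with every amine at this carbon, since the diethylamino group of compound 4, with no ring and no hydrogen-bond donor, goes with stronger inhibition. This step starts from a number level with the ceiling of the read-out, so its full size may not be captured: the limit of > 5000 nM in this assay, at which 1 of the 4 values shown sits.

The two groups differ both in the ring and in the hydrogen-bond donor, so the compounds shown do not say which of these matters. A morpholine or a pyrrolidine at this carbon would begin to separate the two.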